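Carboxymethyl in place of 2-cyanoethyl on the amide

The compounds below may be only part of what the source reports. "The series", "measured", "known", "first", "only" and "open" are said of these compounds alone.

In a functional assay on MCF7 cells (Homo sapiens), read by MTT assay, with a stated time of 48 h (on this read-out higher numbers stand for weaker inhibition and lower numbers for stronger inhibition), compound 1 `CCn1c(C(=O)NCCCN(C)C)ccc1C(CC)(CC)c1ccc(OCC(O)C(C)(C)C)c(C)c1` gives 490 nM. Compound 2 `C#CCNC(=O)c1ccc(C(CC)(CC)c2ccc(OCC(O)C(C)(C)C)c(C)c2)n1CC` gives > 50000 nM, which is a limit and not a number. Compound 3 `CCn1c(C(=O)N(C)CCC#N)ccc1C(CC)(CC)c1ccc(OCC(O)C(C)(C)C)c(C)c1` gives > 50000 nM, also a limit, and so stands at the limit of > 50000 nM in this assay, at which 2 of the 3 values shown sit. Compound 4 `CCn1c(C(=O)N(C)CC(=O)O)ccc1C(CC)(CC)c1ccc(OCC(O)C(C)(C)C)c(C)c1` differs from it by carboxy in place of cyanomethyl on a saturated chain carbon bound to an amide-type nitrogen. The measured steps bearing on this are an at least 100-fold higher number from compound 1 to compound 2 (2.00 log units; beyond the scatter) and an at least 100-fold higher number from compound 1 to compound 3 (2.00 log units; beyond the scatter), both large, and a step that the two limits leave unreadable from compound 2 to compound 3. Like compound 2 and compound 3, compound 4 lacks the (3-(dimethylamino)propyl)amino group of compound 1, so no step beyond the scatter is expected in this assay. The expected outcome is a number no higher from compound 3 to compound 4 (the limit leaves the size open). For compound 4 the estimate is 50000 nM, with an expected range of 20000 nM to 100000 nM.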

Compound 4, half-maximal inhibitory concentration: 25400 nM
Compound 4: middle estimate off by 2.0-fold (0.29 log units), on the high side, within the range that was stated.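

In this assay, carboxymethyl on this amide gives a number rather than a limit, but the steps read an at least 1.9-fold lower number from compound 3 to compound 4 (0.29 log units; that floor lies within the scatter) and an at least 1.9-fold lower number from compound 2 to compound 4 (0.29 log units; that floor lies within the scatter). The gap to the (3-(dimethylamino)propyl)amino amide now has a size, a 52-fold higher number from compound 1 to compound 4 (1.71 log units; beyond the scatter), so this change does not restore the level of that amide. Compound 2 and compound 3 remain limits and not numbers: the limit of > 50000 nM in this assay, at which 2 of the 4 values shown sit.

Open, as far as these compounds go, is which part of the (3-(dimethylamino)propyl)amino group that level depends on. Also open, from the compounds shown here alone, is whether a primary amine or a longer chain ending in a dimethylamino group would hold it.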